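A few compounds are considered here, and "the series" means these few. Any claim that something is new, unique, unknown or untested is made for them only; others in the source may bear on it.

Measured so far:
compound 1 `CCCC(NC(=O)c1nccs1)c1cnc(Nc2ccc(C)nc2)c(Cl)c1`, which in a functional assay on HEK293 cells for negative allosteric modulation of metabotropic glutamate receptor 5 (Homo sapiens), read by HTRF and inositol phosphate accumulation (a higher number here means a weaker inhibitor, a lower number a stronger inhibitor), gives 28.7 nM;
compound 2 `Cc1ccc(Nc2ncc([C@H](NC(=O)c3nccs3)C(C)(C)C)cc2Cl)cn1`, which in this assay gives 30.9 nM.

Compound 2 carries the higher of the two numbers, but its gap to compound 1 lies within the usual scatter, so the two cannot be told apart. Compound 3 `Cc1ccc(Nc2ncc([C@H](NC(=O)c3nccs3)C3CCCCC3)cc2Cl)cn1` keeps the rest of compound 2 and differs in one place: cyclohexyl in place of tert-butyl on a saturated chain carbon bound to an amide-type nitrogen and an aromatic carbon. For the measured compounds named here, no pair of measured compounds shows what this change does here. In this assay a small step is expected, upward if anything, most likely not beyond the scatter. Compound 3 is estimated at 35 nM, between 12 nM and 110 nM, which means an expected step of a 1.1-fold higher number from compound 2 to compound 3 (0.05 log units; within the scatter).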

Compound 3, half-maximal inhibitory concentration: 37.8 nM
The estimate for compound 3 lay 1.1-fold (0.03 log units) below the measured number, within the range that was stated.
By their numbers in this assay, from the lowest: compounds 1, 2 and 3 (each within the scatter of the next).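

With cyclohexyl in place of tert-butyl on this saturated chain carbon, this assay shows a 1.2-fold higher number from compound 2 to compound 3 (0.09 log units; within the scatter) and the two compounds cannot be told apart. So this carbon carries a six-membered non-aromatic ring of carbon only as well as it carries the ringless tert-butyl, a swap that no earlier pair had tested. No data at hand explain this result.

Both groups compared here contain carbon only. On these data alone, what an amine or a carboxylic acid would do on this carbon stays open.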